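Phenyl for naphthalen-2-yl on the amide

A few compounds are considered here, and "the series" means these few. Any claim that something is new, unique, unknown or untested is made for them only; others in the source may bear on it.

Of the compounds shown here, three have been read in a functional assay on MT2 cells (Homo sapiens) for antiproliferative activity, read by MTT assay, with a stated time of 72 h; on this read-out higher numbers stand for weaker inhibition of growth and lower numbers for stronger inhibition of growth. Compound 1 `O=C(COc1c(-c2ccccc2)oc2ccccc2c1=O)Nc1ccc2ccccc2c1` returns only a limit of the assay, > 10000 nM. Compound 2 `O=C(COc1ccc2c(=O)c(-c3ccccc3)coc2c1)Nc1ccc2ccccc2c1` gives 7680 nM, and compound 3 `O=C(COc1ccc2c(=O)cc(-c3ccccc3)oc2c1)Nc1ccc(F)cc1` gives 6410 nM. These two numbers lie within the scatter of each other, so compound 2 stands level with its nearest neighbour, and both show weak inhibition of growth.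

Compound 4 `O=C(COc1ccc2c(=O)c(-c3ccccc3)coc2c1)Nc1ccccc1` keeps the core of compound 2 and carries one change: phenyl in place of naphthalen-2-yl on an amide-type nitrogen. In words, phenyl replaces naphthalen-2-yl on an amide-type nitrogen. For the measured compounds named here, no measured pair isolates this change. Compound 3 has a single aromatic ring on its amide nitrogen and still gives 6410 nM, though on a different core, so a large loss is not expected. A small move toward a higher number is expected in this assay, possibly none beyond the scatter, and a result at the limit would fit. The expected change is a 1.1-fold higher number from compound 2 to compound 4 (0.04 log units; within the scatter). For compound 4 the estimated value is 8500 nM, with an expected range from 3500 nM to 20000 nM.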

Compound 4, concentration for 50% growth inhibition: > 10000 nM
Compound 4 ended at the assay's limit; the forecaster's own chance of this, stated with the estimate: 35%; middle value at least 1.1-fold (0.07 log units) away from the limit.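

In this assay, this position now has its first readable step: an at least 1.3-fold higher number from compound 2 to compound 4 (0.11 log units; that floor lies within the scatter), for phenyl in place of naphthalen-2-yl on an amide-type nitrogen. For the compounds shown here, only a floor is available, so the data establish no firm loss on removing the second aromatic ring, only that compound 4 shows no stronger inhibition of growth than compound 2. The full size of the step stays unknown because the read-out stops at a limit: the limit of > 10000 nM in this assay, at which 2 of the 4 values shown sit.

Still open, on these data alone, is whether any group on this amide-type nitrogen can bring the core of compound 2 clear of this weak range. A benzyl group on that nitrogen, or a carboxylic acid or a dimethylamino group on the phenyl of compound 4, would test how far this position can move the read-out in this assay.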